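Oxime ether series: bromo to methyl on the aryl ring

A few compounds are considered here, and "the series" means these few. Any claim that something is new, unique, unknown or untested is made for them only; others in the source may bear on it.

Measured so far:
- Compound 1 `Clc1ccc(CO/N=C/c2c(-c3ccc(Br)cc3)nc3sccn23)cc1Cl`: in an assay on HepG2 cells for agonist activity at nuclear receptor subfamily 1 group I member 3 (Homo sapiens), read by a luciferase reporter, with a stated time of 23 h (on this read-out higher numbers stand for an effect only at larger amounts of compound and lower numbers for an effect already at smaller amounts), compound 1 gives 480 nM.
- Compound 2 `Clc1ccccc1CO/N=C/c1c(-c2ccc3ccccc3c2)nc2occn12`: in this assay compound 2 gives 1100 nM.

Compound 1 holds the lowest of the two numbers; compound 2 stands higher, and the gap between the two is beyond the scatter. For the measured compounds named here, the two compounds differ in more than one place, so no single step between them is available, and only their two values can be compared.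

Compound 3 `Cc1ccc(-c2nc3sccn3c2/C=N/OCc2ccc(Cl)c(Cl)c2)cc1` has not yet been measured. It differs from compound 1 by methyl in place of bromo on an aromatic carbon, a like-for-like exchange of one heavy atom for another at the same place on the ring.

Going by the values given here, no step between measured compounds is at hand to calibrate this change. Given the small size of the exchange, only a modest shift is expected, if any, most likely toward a slightly higher number; the expected step in this assay is a 1.5-fold higher number from compound 1 to compound 3 (0.16 log units; within the scatter). For compound 3 the estimate in this assay is 700 nM, with a range from 300 nM to 1600 nM.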

Compound 3, half-maximal effective concentration: 490 nM
Estimate against measurement, compound 3: 1.4-fold (0.15 log units) above; measured number inside the range.
By their numbers in this assay, from the lowest: compounds 1 and 3 (each within the scatter of the next); then compound 2.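

In this assay, for the compounds shown here, the exchange of bromo for methyl on an aromatic carbon, para to a large group, reads as a 1.0-fold higher number from compound 1 to compound 3 (0.01 log units; within the scatter), and this is the first comparison that isolates a single place. With the rest of compound 1 held fixed, the 4-bromophenyl and 4-methylphenyl groups cannot be told apart on this read-out, so this pair gives no sign that the choice between these two groups matters at this place. No measurement bears on why the two groups give matching numbers.

This single pair leaves open how far the finding reaches: an amine, a carboxylic acid or a longer chain such as butyl at the same place on the ring would show whether groups unlike bromo and methyl also leave the number within the scatter, and a plain hydrogen would show whether any group is needed there. Going by these compounds, it also remains open whether the same exchange gives a matching pair on a core other than that of compound 1, or with a different group on the oxime ether.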